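Swapping Phenoxy for 4-Chlorophenyl on the Saturated Ring

The source may hold more compounds than are shown below. What is called first, only, known or untested is meant among the compounds shown, and "the series" means these compounds.

Of the compounds shown here, three sharing one core have been measured in an ADME assay on liver for metabolic stability, with Liver microsome (Homo sapiens) as the target, using microsomes; on this read-out higher numbers stand for fast clearance and lower numbers for slow clearance. Compound 1 (`N#Cc1ccc(C2CCN(C(=O)Nc3cc(-c4ccccn4)n[nH]3)CC2)cc1`) gives 25.3 mL.min-1.g-1, compound 2 (`O=C(Nc1cc(-c2ccccn2)n[nH]1)N1CCC(c2ccc(F)cc2)CC1`) gives 42.5 mL.min-1.g-1, and compound 3 (`O=C(Nc1cc(-c2ccccn2)n[nH]1)N1CCC(Oc2ccccc2)CC1`) gives 27.3 mL.min-1.g-1. Compound 3 lies within the scatter of both others, as shown by a 1.1-fold higher number from compound 1 to compound 3 (0.03 log units; within the scatter) and by a 1.6-fold lower number from compound 2 to compound 3 (0.19 log units; within the scatter).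

The next compound, compound 4 (`O=C(Nc1cc(-c2ccccn2)n[nH]1)N1CCC(c2ccc(Cl)cc2)CC1`), carries 4-chlorophenyl in place of phenoxy on a saturated ring carbon. Within the data shown here, no measured step makes this exact exchange. The closest evidence is the step that puts phenoxy in place of 4-fluorophenyl, a 1.6-fold lower number from compound 2 to compound 3 (0.19 log units; within the scatter), and the step that puts phenoxy in place of 4-cyanophenyl, a 1.1-fold higher number from compound 1 to compound 3 (0.03 log units; within the scatter). Fluoro in place of cyano on an aromatic carbon, a 1.7-fold higher number from compound 1 to compound 2 (0.23 log units; within the scatter), also stays within the scatter. Compound 2, at 42.5 mL.min-1.g-1, is the closest measured match, so a modest rise is the likelier direction, but no change beyond the scatter is expected in this assay. The expected size of the change is a 1.4-fold higher number from compound 3 to compound 4 (0.14 log units; within the scatter). For compound 4 the estimated value is 38 mL.min-1.g-1, with an expected range from 20 mL.min-1.g-1 to 70 mL.min-1.g-1.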

Compound 4, intrinsic clearance in microsomes: 30 mL.min-1.g-1
Beside the measured number, compound 4's estimate is 1.3-fold (0.10 log units) above it; the range from low to high includes it.
By their numbers in this assay, from the lowest: compounds 1, 3, 4 and 2 (each within the scatter of the next).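

In this assay, the direct exchange on the saturated ring carbon (a 1.1-fold higher number from compound 3 to compound 4 (0.04 log units; within the scatter)) stays within the scatter, even though it removes the hydrogen-bond acceptor counted on phenoxy, so that acceptor shows no readable effect on this read-out. The aromatic carbon that carries the halogen or nitrile now has a third group, and neither chloro in place of fluoro (a 1.4-fold lower number from compound 2 to compound 4 (0.15 log units; within the scatter)) nor chloro in place of cyano (a 1.2-fold higher number from compound 1 to compound 4 (0.07 log units; within the scatter)) leaves the scatter. Across these four compounds, then, no exchange at either place separates one compound from another in this assay, and the small differences among their numbers cannot be given an order.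

The compounds shown leave open whether any group on the saturated ring carbon can move the read-out beyond the scatter, for instance an amine or a carboxylic acid in place of 4-chlorophenyl, or a longer chain carrying the aromatic ring. Nothing available bears on what lies behind this flat result.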